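Chloro Added to the Naphthyloxy Ring of a Triazine

The source may hold more compounds than are shown below. What is called first, only, known or untested is meant among the compounds shown, and "the series" means these compounds.

This account concerns a small set of triazines carrying a nitrile-bearing aniline and a naphthyloxy group, tested in an ADME assay on MT4 cells (Homo sapiens) for cytotoxicity, read by MTT assay, with a stated time of 4 days; on this read-out higher numbers stand for lower toxicity in this test and lower numbers for higher toxicity in this test. Compound 1 `N#Cc1ccc(Nc2nc(N)nc(Oc3cccc4ccccc34)n2)cc1` gives 39100 nM. Compound 2 `CCCNc1nc(Nc2ccc(C#N)cc2)nc(Oc2cccc3ccccc23)n1` gives 29500 nM, the lowest of the three numbers; compound 3 `CCNc1nc(Nc2ccc(C#N)cc2)nc(Oc2ccc(Cl)c3ccccc23)n1` gives 208000 nM. Among the measured compounds shown here, the one single-point step measured, a 1.3-fold lower number from compound 1 to compound 2 (0.12 log units; within the scatter), concerns an alkyl group on a nitrogen and does not touch the change now considered. Compound 4 `CCCNc1nc(Nc2ccc(C#N)cc2)nc(Oc2ccc(Cl)c3ccccc23)n1` differs from compound 2 by chloro in place of hydrogen on an aromatic carbon. For the measured compounds named here, no measured step isolates this change. What the numbers of compound 2 and compound 3 show is that the chloro-bearing compound 3 stands well above compound 2, although those two also differ in the alkyl on the nitrogen, a change that in the step from compound 1 to compound 2 stayed within the scatter. Going by the values given here, compound 4 is therefore expected to move upward, by a 3.7-fold higher number from compound 2 to compound 4 (0.57 log units; beyond the scatter), with a wide range because only one chloro-bearing comparison exists. The estimate for compound 4 is 110000 nM, between 35000 nM and 350000 nM.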

Compound 4, half-maximal cytotoxic concentration: 182000 nM
Compound 4: the middle estimate sits 1.7-fold (0.22 log units) below what was measured; the measured number falls inside the stated range.
By their numbers in this assay, from the lowest: compounds 2 and 1 (each within the scatter of the next); then compounds 4 and 3 (each within the scatter of the next).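

With chloro in place of hydrogen on an aromatic carbon, para to a large group, the change now stands alone in this assay as a 6.2-fold higher number from compound 2 to compound 4 (0.79 log units; beyond the scatter) and lies beyond the scatter, so a higher number goes with this change even with the propyl group held constant. The ethyl and propyl compounds that both carry chloro are not separated, with a 1.1-fold lower number from compound 3 to compound 4 (0.06 log units; within the scatter) within the scatter, which means that the chain difference between them does not account for the distance seen earlier between the chloro-bearing compound 3 and compound 2. Nothing available explains why chloro at this carbon goes with lower toxicity in this test.

Still open, as far as these compounds go, is whether bromo, fluoro or methoxy on the same aromatic carbon would give a step of similar size. From the compounds shown here alone, it is also open whether chloro would act alike on compound 1, which has no alkyl group on that nitrogen, or alongside a longer chain such as butyl.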